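This account rests on a few compounds, and the source may have more. Where it says the series, first, only, none or still open, it means among the compounds named here.

Compound 3 `COc1cc2ncnc(Nc3ccc(Cl)cc3)c2cc1OCCCCC(=O)Nc1ccc(S(N)(=O)=O)cc1` gives 31800 nM in a functional assay on NCI-H1975 cells (Homo sapiens) for antiproliferative activity, read by MTT assay, with a stated time of 72 h (on this read-out higher numbers stand for weaker inhibition and lower numbers for stronger inhibition), the highest of the two numbers shown. Its nearest neighbour is compound 1 `C#Cc1cccc(Nc2ncnc3cc(OC)c(OCCCCC(=O)Nc4ccc(S(N)(=O)=O)cc4)cc23)c1`, which in this assay gives 18800 nM; the step of a 1.7-fold higher number from compound 1 to compound 3 (0.23 log units; within the scatter) stays within the scatter. Compound 2 `COc1cc2ncnc(Nc3ccc(F)cc3)c2cc1OCCCCC(=O)Nc1ccc(S(N)(=O)=O)cc1` reports only a limit in this assay, > 40000 nM. That limit is the limit of > 40000 nM in this assay, at which 1 of the 3 values shown sits. Across the measured steps, an at least 2.1-fold higher number from compound 1 to compound 2 (0.32 log units; beyond the scatter) and an at least 1.2-fold lower number from compound 2 to compound 3 (0.09 log units; that floor lies within the scatter), swapping the group on the aniline ring moves the read-out little.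

Compound 4 `COc1cc2ncnc(Nc3ccc(OC(F)(F)F)cc3)c2cc1OCCCCC(=O)Nc1ccc(S(N)(=O)=O)cc1` differs from compound 3 by trifluoromethoxy in place of chloro on an aromatic carbon. Among the measured compounds shown here, the steps that bear on this exchange are an at least 1.2-fold lower number from compound 2 to compound 3 (0.09 log units; that floor lies within the scatter), which is within the scatter, and an at least 2.1-fold higher number from compound 1 to compound 2 (0.32 log units; beyond the scatter) and a 1.7-fold higher number from compound 1 to compound 3 (0.23 log units; within the scatter), all small. A further swap of the same kind is therefore expected to give no step beyond the scatter, with a slight lean towards a higher number. Compound 4 is expected to give about 33000 nM in this assay, between 14000 nM and 80000 nM, which means an expected step of a 1.0-fold higher number from compound 3 to compound 4 (0.02 log units; within the scatter).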

Compound 4, half-maximal inhibitory concentration: 8770 nM
Beside the measured number, compound 4's estimate is 3.8-fold (0.58 log units) above it; the whole stated range lies above it.
By their numbers in this assay, from the lowest: compound 4; then compounds 1 and 3 (each within the scatter of the next). At a limit, above all of these: compound 2.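

Trifluoromethoxy in place of chloro on an aromatic carbon gives a 3.6-fold lower number from compound 3 to compound 4 (0.56 log units; beyond the scatter), so this position, where fluoro and chloro could not be told apart, does respond to the group it carries. The same exchange against fluoro gives an at least 4.5-fold lower number from compound 2 to compound 4 (0.65 log units; beyond the scatter), and the change from the 3-ethynylphenyl group gives a 2.1-fold lower number from compound 1 to compound 4 (0.33 log units; beyond the scatter), which makes compound 4 the most potent of the compounds shown in this assay. The step from compound 2 is only a floor, as compound 2 reports a limit and not a number: the limit of > 40000 nM in this assay, at which 1 of the 4 values shown sits.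

On these data alone, whether a methoxy or trifluoromethyl group at the same place would give a similar step remains open, so the step cannot yet be tied to the oxygen or to the fluorines. Also open, as far as these compounds go, is how a shorter chain in the linker would act together with trifluoromethoxy.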